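The source may report more compounds than this note shows. Statements on the series, on what has been measured and on what is new or still open speak of the compounds shown alone.

For the measured compounds named here, in a functional assay (Left cardiac atrium, Cavia porcellus), with a stated time of 30 min (on this read-out higher numbers stand for an effect only at larger amounts of compound and lower numbers for an effect already at smaller amounts), compound 3 (`COc1cccc(C2(OC(C)C)SC=C(C)n3c2noc3=O)c1`) gives 64 nM as the lowest of the three numbers so far. Compound 2 (`COc1cccc(C2(OCC(F)(F)F)SC=C(C)n3c2noc3=O)c1`) stands at 320 nM in the same read-out, and compound 1 (`COc1ccc(C2(OCC3CCCCC3)SC=C(C)n3c2noc3=O)cc1`) stands at 660 nM there; both lie beyond the scatter from compound 3.

The next structure is compound 4 (`COc1cccc(C2(OCC3CCCCC3)SC=C(C)n3c2noc3=O)c1`), which has cyclohexylmethyl in place of isopropyl on the oxygen on a saturated carbon (cyclohexylmethyl in place of isopropyl on an oxygen on a saturated carbon).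

Going by the values given here, only one measured step changes the group at this place: a 5.0-fold lower number from compound 2 to compound 3 (0.70 log units; beyond the scatter) is a modest change, with isopropyl in place of 2,2,2-trifluoroethyl. That step shows the number moving with the group on this oxygen, but neither group in it contains a ring. Among the compounds with values here, compound 1 at 660 nM is the only measured compound with cyclohexylmethyl on this oxygen, although it differs from compound 4 elsewhere in the structure. Within the data shown here, no measured pair isolates that other difference, so compound 1 serves only as a rough guide.

In this assay, among the measured compounds shown here, an expected 3.9-fold higher number from compound 3 to compound 4 (0.59 log units; beyond the scatter) means a higher number, similar in size to the one measured step. For compound 4 the estimate is 250 nM with an expected range of 70 nM to 800 nM in this read-out.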

Compound 4, half-maximal effective concentration: 650 nM
The estimate for compound 4 lay 2.6-fold (0.41 log units) below the measured number; low and high end bracket the measured number.
By their numbers in this assay, from the lowest: compound 3; then compound 2; then compounds 4 and 1 (each within the scatter of the next).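

Working notes: in this assay, cyclohexylmethyl on this oxygen gives a 10-fold higher number from compound 3 to compound 4 (1.01 log units; beyond the scatter) against isopropyl and a 2.0-fold higher number from compound 2 to compound 4 (0.31 log units; beyond the scatter) against 2,2,2-trifluoroethyl, so with 3-methoxyphenyl held constant the three groups now read in order, with isopropyl lowest, 2,2,2-trifluoroethyl in the middle and cyclohexylmethyl highest, and the first group carrying a ring gives the largest step at this place. The exchange of 4-methoxyphenyl for 3-methoxyphenyl on the saturated ring carbon gives a 1.0-fold lower number from compound 1 to compound 4 (0.01 log units; within the scatter) and so does not separate the two compounds in this read-out when cyclohexylmethyl sits on the oxygen, which makes compound 1 a direct comparator for compound 4 rather than the rough guide it was before. Nothing at hand bears on the origin of these steps.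

On these data alone, whether the number at this place follows the count of carbons or the presence of the ring stays open, and a cyclopropylmethyl, a tert-butyl or a straight butyl chain on this oxygen would be needed to separate the two readings. Also open, as far as these compounds go, is whether 3-methoxyphenyl and 4-methoxyphenyl stay equivalent with isopropyl on the oxygen, and what an amine or a carboxylic acid on this chain would do to the number.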